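The source may hold more compounds than are shown below. What is called first, only, known or untested is meant among the compounds shown, and "the series" means these compounds.

In a functional assay on A-375 cells (Homo sapiens) for antiproliferative activity (a higher number here means a weaker inhibitor, a lower number a stronger inhibitor), three compounds that differ only in the fluorinated phenyl group on a saturated chain carbon bound to an amine nitrogen in a ring have been measured. Compound 1 (`O=C(Nc1ccc(-c2cscn2)cc1)C1CCCN(Cc2cccc(F)c2)C1`) gives 2450 nM, compound 2 (`O=C(Nc1ccc(-c2cscn2)cc1)C1CCCN(Cc2cc(F)cc(F)c2)C1`) gives 1360 nM and compound 3 (`O=C(Nc1ccc(-c2cscn2)cc1)C1CCCN(Cc2cccc(F)c2F)C1`) gives 1480 nM. Compound 3 therefore stands within the scatter of both other compounds, and none of the three can be separated from the others.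

Compound 4 (`O=C(Nc1ccc(-c2cscn2)cc1)C1CCCN(Cc2cccc(C(F)(F)F)c2)C1`) brings a new change, 3-(trifluoromethyl)phenyl in place of 2,3-difluorophenyl on a saturated chain carbon bound to an amine nitrogen in a ring: 3-(trifluoromethyl)phenyl in place of 2,3-difluorophenyl. Going by the values given here, no measured compound carries trifluoromethyl, so the evidence is indirect. Adding fluoro gave a 1.8-fold lower number from compound 1 to compound 2 (0.26 log units; within the scatter) and a 1.7-fold lower number from compound 1 to compound 3 (0.22 log units; within the scatter), while exchanging one difluorophenyl for the other gave a 1.1-fold higher number from compound 2 to compound 3 (0.04 log units; within the scatter). As far as these compounds go, all three steps are small, so no step beyond the scatter is expected, although the new group remains untested. The expected change is a 1.2-fold higher number from compound 3 to compound 4 (0.09 log units; within the scatter). For compound 4 the estimated value is 1800 nM, with an expected range from 800 nM to 4000 nM.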

Compound 4, half-maximal inhibitory concentration: > 20000 nM
Compound 4: only a limit was reported; the forecaster's own chance of this, stated with the estimate: 3%; at least 11-fold (1.04 log units) between middle value and limit.
By their numbers in this assay, from the lowest: compounds 2, 3 and 1 (each within the scatter of the next). At a limit, above all of these: compound 4.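

In this assay compound 4 is reported only as a limit, not as a number: the limit of > 20000 nM in this assay, at which 1 of the 4 values shown sits.

Until now, the fluorinated phenyl groups on the saturated chain carbon bound to an amine nitrogen in a ring could not be told apart, but 3-(trifluoromethyl)phenyl at this place gives an at least 13-fold higher number from compound 3 to compound 4 (1.13 log units; beyond the scatter), an at least 14-fold higher number from compound 2 to compound 4 (1.16 log units; beyond the scatter) and an at least 8.1-fold higher number from compound 1 to compound 4 (0.91 log units; beyond the scatter). Going by these compounds alone, the last of these steps is a single change, trifluoromethyl in place of fluoro on an aromatic carbon, so this place does respond to the group it carries, even though the earlier steps gave no sign of it.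

As far as these compounds go, how far compound 4 lies past its limit stays open. From the compounds shown here alone, it is also open whether a methyl, chloro or methoxy group in place of fluoro would stay with compounds 1, 2 and 3 or go the way of compound 4.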